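The source may hold more compounds than are shown below. What is called first, only, known or untested is meant among the compounds shown, and "the series" means these compounds.

Of the compounds shown here, three built on one shared core have been measured in a functional assay on K562 cells (Homo sapiens) for cytotoxicity, read by MTT assay; on this read-out higher numbers stand for weaker inhibition and lower numbers for stronger inhibition. Compound 1 `C#CCOc1cc(/C=C/C(=O)c2ccc(OC)c3c2OC(C)(C)C=C3)ccc1OC` gives > 10000 nM, which is a limit of the assay rather than a number. Compound 2 `C=CCOc1cc(/C=C/C(=O)c2ccc(OC)c3c2OC(C)(C)C=C3)ccc1OC` likewise gives only the limit > 10000 nM. Compound 3 `COc1ccc(/C=C/C(=O)c2ccc(OC)c3c2OC(C)(C)C=C3)cc1OC(=O)C1CC1`, in which a cyclopropylcarbonyl replaces the propargyl or allyl group, gives 410 nM. The step that the two limits leave unreadable from compound 1 to compound 2 cannot be read, since both values sit at the limit of > 10000 nM in this assay, at which 2 of the 3 values shown sit. The steps of an at least 24-fold lower number from compound 1 to compound 3 (1.38 log units; beyond the scatter) and an at least 24-fold lower number from compound 2 to compound 3 (1.38 log units; beyond the scatter) are the only readable ones, and both are large.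

Compound 2 therefore stands at the weak end of what is shown, at the limit it shares with compound 1, while compound 3 alone gives a number.

Compound 4 `COc1ccc(/C=C/C(=O)c2ccc(OC)c3c2OC(C)(C)C=C3)cc1CS(C)(=O)=O` has not been measured. It differs from compound 2 by (methylsulfonyl)methyl in place of allyloxy on an aromatic carbon. The measured steps that bear on this change are an at least 24-fold lower number from compound 2 to compound 3 (1.38 log units; beyond the scatter) and an at least 24-fold lower number from compound 1 to compound 3 (1.38 log units; beyond the scatter), in which the allyl or propargyl ether gave way to an ester; the group entering here is not an ester, so those steps guide only loosely. One expects a moderate move toward lower numbers, an at least 1.6-fold lower number from compound 2 to compound 4 (0.22 log units; that floor lies within the scatter), and estimates compound 4 in this assay at 6000 nM, within 1500 nM to 30000 nM.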

Compound 4, half-maximal inhibitory concentration: 9240 nM
Beside the measured number, compound 4's estimate is 1.5-fold (0.19 log units) below it; the measured number falls inside the stated range.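

Among these compounds, at this aromatic carbon, ortho to a methoxy group, (methylsulfonyl)methyl is the first group other than the ester to give a number in this assay, yet the steps from the two ethers are only floors: an at least 1.0-fold lower number from compound 2 to compound 4 (0.03 log units; that floor lies within the scatter) and an at least 1.0-fold lower number from compound 1 to compound 4 (0.03 log units; that floor lies within the scatter). Neither floor shows a gain that can be told from the scatter. Set against the ester, the same position shows a large change, a 23-fold higher number from compound 3 to compound 4 (1.35 log units; beyond the scatter), so compound 3 remains the most potent of the four, and a non-ester group with more heavy atoms than allyloxy does not bring the number near that of the (cyclopropylcarbonyl)oxy group.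

As far as these compounds go, the step from compound 1 to compound 2 cannot be read, because both compounds rest on a limit: the limit of > 10000 nM in this assay, at which 2 of the 4 values shown sit. It also stays open whether the lower number of compound 3 goes with the ester link or with its cyclopropane ring, a question that an acetyl ester or a cyclopropylmethyl ether at this carbon would address.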